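Swapping the Aromatic Group on the Shared Core

A few compounds are considered here, and "the series" means these few. Any claim that something is new, unique, unknown or untested is made for them only; others in the source may bear on it.

Compound 1, `CCC(C(=O)N1CCN(c2ccccc2Cl)CC1)N1C(=O)CCC1=O`: 50%
Compound 2, `CCC(C(=O)N1CCN(c2ccc(F)cc2)CC1)N1C(=O)CCC1=O`: 25%

Of the compounds shown here, two have been tested in a functional assay on the whole organism (strain Swiss) with Mus musculus as the target, in the maximal electroshock model, with a stated time of 1 h, at a dose of 300 mg/kg by the intraperitoneal route; a higher number here means a stronger effect of the compound at the dose given, a lower number a weaker effect. For the measured compounds named here, compound 1 gives 50%, and compound 2 gives 25%, the lowest of the two numbers; the only measured step, a number 25 percentage points lower from compound 1 to compound 2 (beyond the scatter), set compound 2 below compound 1 by more than the scatter. Compound 3, `CCC(C(=O)N1CCN(c2cccc(C)c2)CC1)N1C(=O)CCC1=O`, has not yet been measured. It differs from compound 2 in one place: 3-methylphenyl in place of 4-fluorophenyl on an amine nitrogen in a ring. Going by the values given here, the one measured step concerns this same place on the shared core, so it is the only guide, and it shows that exchanging the aromatic group there can move the read-out by a modest amount in either direction. Among the compounds with values here, no measured pair shows the present exchange itself. Within the data shown here, compound 3 is therefore expected to land near the middle of the two known numbers, at about 35%, within 10% to 60%. Relative to compound 2 this estimate means a number 10 percentage points higher from compound 2 to compound 3 (within the scatter).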

Compound 3, a percentage reported as activity, at one dose (the size of the read-out at that dose, not a potency): 75%
Estimate against measurement, compound 3: 40 percentage points below, and the stated range ends below it.
By their numbers in this assay, from the lowest: compound 2; then compound 1; then compound 3.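

Changing the aromatic group on this amine nitrogen can raise the read-out as well as lower it in this assay: 3-methylphenyl in place of 4-fluorophenyl gives a number 50 percentage points higher from compound 2 to compound 3 (beyond the scatter) and is the larger of the two new steps, while 3-methylphenyl in place of 2-chlorophenyl gives a number 25 percentage points higher from compound 1 to compound 3 (beyond the scatter) as the modest one. Among these three compounds, compound 3 therefore has the highest number, so this position can support a stronger effect than the first two compounds showed. Nothing available explains why the 3-methylphenyl group gives this result.

Each exchange alters both the group carried by the phenyl ring and where it sits, so the contribution of each remains unseparated. On these data alone, how a plain phenyl or a pyridine ring would behave at this position also remains open.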